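Compound 3 and a Shifted Methyl Group

The source may report more compounds than this note shows. Statements on the series, on what has been measured and on what is new or still open speak of the compounds shown alone.

Compound 1 `Cc1ccc(C(=O)N(C(=S)OCCN2C(=O)c3ccccc3C2=O)c2ccc(Cl)cc2)cc1` reads > 100000 nM (a limit)
Compound 2 `Cc1ccc(N(C(=O)c2cccc(C)c2)C(=S)OCCN2C(=O)c3ccccc3C2=O)cc1` reads > 100000 nM (a limit)

In an ADME assay on MT4 cells (Homo sapiens) for cytotoxicity, read by MTT assay (a lower number here means that less compound is tolerated, a higher number that more compound is tolerated), compound 2 reads > 100000 nM, which is a limit of the assay and not a number. Compound 1 reads > 100000 nM, likewise a limit. Among the compounds with values here, both compounds therefore stand at the limit of > 100000 nM in this assay, at which 2 of the 2 values shown sit, and no step between them can be read.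

Compound 3 `Cc1ccc(C(=O)N(C(=S)OCCN2C(=O)c3ccccc3C2=O)c2ccc(C)cc2)cc1` has the same atoms as compound 2, joined differently. The change is 4-methylphenyl in place of 3-methylphenyl on a carbonyl carbon. Within the data shown here, no step between measured compounds is available to size this change.

The expected a number no higher from compound 2 to compound 3 (the limit leaves the size open) lies within the usual scatter, with no direction to be named. That expectation rests on compound 2 and its limit of > 100000 nM in this assay. For compound 3 the estimated half-maximal cytotoxic concentration is 100000 nM, with an expected range from 50000 nM to 200000 nM. The assay is expected to report only a limit once more.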

Compound 3, half-maximal cytotoxic concentration: 83000 nM
For compound 3 the middle estimate is 1.2-fold (0.08 log units) above the measured one; low and high end bracket the measured number.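

In this assay compound 3 gives 83000 nM, the first number among the compounds shown that is not a limit, so this series now has a reading that can anchor a step. The change to 4-methylphenyl in place of 3-methylphenyl on a carbonyl carbon comes with an at least 1.2-fold lower number from compound 2 to compound 3 (0.08 log units; that floor lies within the scatter), and methyl in place of chloro on an aromatic carbon comes with an at least 1.2-fold lower number from compound 1 to compound 3 (0.08 log units; that floor lies within the scatter). Each of these is only a floor, so neither change has a full size yet, since the other two compounds sit at the top of the range that the assay reports: the limit of > 100000 nM in this assay, at which 2 of the 3 values shown sit.

The compounds shown leave open how the number would respond if an amine, a carboxylic acid or a longer chain such as ethyl took the place of the methyl on the 4-methylphenyl group. They also leave open how large either change truly is, as compound 1 and compound 2 each offer only a limit and no number to measure from.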